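Swapping Ethyl for Cyclobutyl on a Second Core

The compounds below may be only part of what the source reports. "The series", "measured", "known", "first", "only" and "open" are said of these compounds alone.

In an ADME assay on Vero cells (Chlorocebus sabaeus) for cytotoxicity, read by CellTiter-Glo, with a stated time of 72 h (a lower number here means that less compound is tolerated, a higher number that more compound is tolerated), compound 1 `CCNc1n[n+]([O-])c2cc(OC)ccc2[n+]1[O-]` gives 16 ug/mL. Compound 2 `COc1ccc2c(c1)[n+]([O-])nc(NC1CCC1)[n+]2[O-]` carries cyclobutyl in place of ethyl on a nitrogen on an aromatic ring and in this assay compound 2 gives 9.8 ug/mL; the step is a 1.6-fold lower number from compound 1 to compound 2 (0.21 log units; within the scatter). Compound 3 `CCNc1n[n+]([O-])c2cc(C)c(OC)cc2[n+]1[O-]` reaches only a limit in this assay, > 100 ug/mL. Its core differs from that of compound 1, and the difference between the two cores is not broken down here. Compound 4 `COc1cc2c(cc1C)[n+]([O-])nc(NC1CCC1)[n+]2[O-]` is not yet measured; it carries cyclobutyl in place of ethyl on a nitrogen on an aromatic ring, the same change as before, made on the core of compound 3. The step from compound 3 to compound 4 is expected to be small, a number no higher from compound 3 to compound 4 (the limit leaves the size open), because the same change earlier produced a 1.6-fold lower number from compound 1 to compound 2 (0.21 log units; within the scatter). Since the limit of > 100 ug/mL in this assay, at which 1 of the 3 values shown sits, applies to compound 3, compound 4 is estimated at 100 ug/mL, most likely again reported only as a limit.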

Compound 4, half-maximal cytotoxic concentration: > 50 ug/mL
Compound 4: only a limit was reported; the forecaster's own chance of this, stated with the estimate: 70%; the middle value is on the limit's open side.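

Compound 3 and compound 4 are each reported only as a limit, and the step between them cannot be read. Still open, from the compounds shown here alone, is whether cyclobutyl in place of ethyl changes the number in this assay on this core at all.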